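Replacing a terminal amino group with an aryl-bearing fragment

A few compounds are considered here, and "the series" means these few. Any claim that something is new, unique, unknown or untested is made for them only; others in the source may bear on it.

Measured so far:
compound 1, `CC1=CC[C@@H]([C@@](C)(O)CCCC(C)(C)NC(=S)NN)CC1`: 17200 nM
compound 2, `CC1=CC[C@@H]([C@@](C)(O)CCCC(C)(C)NC(=S)N/N=C\c2cccc([N+](=O)[O-])c2)CC1`: 8510 nM

Both compounds share the same core and were tested in a functional assay on OVCAR-3 cells (Homo sapiens) for cytotoxicity, read by sulforhodamine B assay; a lower number here means a stronger inhibitor of growth, a higher number a weaker inhibitor of growth. Compound 1 gives 17200 nM, the higher of the two numbers, so it is the weaker growth inhibitor here. Compound 2 gives 8510 nM, a lower number that lies beyond the usual scatter. These two compounds differ at more than one place, so their gap cannot be assigned to a single change.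

Compound 3, `CC1=CC[C@@H]([C@@](C)(O)CCCC(C)(C)NC(=S)N/N=C(/C)c2ccccc2)CC1`, has not yet been measured. Compared with compound 1, the change is a group of 9 heavy atoms (8 carbon, 1 nitrogen; one six-membered aromatic ring of carbon only) in place of one nitrogen atom, on an amide-type nitrogen. The part that enters contains one six-membered aromatic ring of carbon only and one double bond outside aromatic rings, and it carries no hydrogen-bond donor.

Compound 2, which also carries a larger group at this position, gives 8510 nM, while compound 1 gives 17200 nM; on that basis a modest step toward a lower number is expected. For compound 3 the estimate in this assay is 9000 nM with a range from 3500 nM to 25000 nM, which amounts to an expected 1.9-fold lower number from compound 1 to compound 3 (0.28 log units; within the scatter).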

Compound 3, concentration for 50% growth inhibition: 14300 nM
Compound 3: the middle estimate sits 1.6-fold (0.20 log units) below what was measured, within the range that was stated.
By their numbers in this assay, from the lowest: compounds 2, 3 and 1 (each within the scatter of the next, the first and the last beyond it).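

In this assay, the step is a 1.2-fold lower number from compound 1 to compound 3 (0.08 log units; within the scatter), which lies within the usual scatter, so this assay does not separate the two compounds. On the amide-type nitrogen, a group of 9 heavy atoms with a six-membered aromatic ring of carbon only can therefore replace the small amino group, a hydrogen-bond donor, without a measurable difference in growth inhibition, even though the part that enters carries no hydrogen-bond donor. Nothing measured here explains this result.

This single step does not show how the aromatic ring and the methyl group on the double-bonded carbon each contribute. Going by these compounds, the effect of an amine or a carboxylic acid on the aromatic ring, or of a longer chain in place of that methyl group, remains open.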